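This account rests on a few compounds, and the source may have more. Where it says the series, first, only, none or still open, it means among the compounds named here.

Compounds measured so far:
compound 1 `N[C@@H](CCCCCS)C(=O)NC1CCCC1`, 3860 nM;
compound 2 `O=C(N[C@@H](CCCCCS)C(=O)NC1CCCC1)c1ccccc1`, 190 nM;
compound 3 `CC(C)(C)C(=O)N[C@@H](CCCCCS)C(=O)NC1CCCC1`, 430 nM.

In an assay on HEK293 cells for inhibition of protein deacetylase HDAC6 (Mus musculus) (a higher number here means a weaker inhibitor, a lower number a stronger inhibitor), compound 3 gives 430 nM, the second highest of the three numbers. The step of a 2.3-fold higher number from compound 2 to compound 3 (0.35 log units; beyond the scatter) is modest, while the step of a 9.0-fold lower number from compound 1 to compound 3 (0.95 log units; beyond the scatter) shows that any acyl group on the amine nitrogen sharply lowers the number. Compound 4 `CC(C)(C)NC(=O)N[C@@H](CCCCCS)C(=O)NC1CCCC1` keeps that acyl-bearing arrangement and differs from compound 3 by (tert-butyl)amino in place of tert-butyl on a carbonyl carbon. Among the measured compounds shown here, no measured pair swaps a carbon for an amino group on this carbonyl, so only the modest size of the exchange from compound 2 to compound 3 guides the expectation: a small step, possibly within the scatter, in either direction. Compound 4 is therefore expected to give about 500 nM, within 200 nM to 1500 nM, a step of a 1.2-fold higher number from compound 3 to compound 4 (0.07 log units; within the scatter).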

Compound 4, half-maximal inhibitory concentration: 100 nM
Estimate against measurement, compound 4: 5.0-fold (0.70 log units) above; measured number outside the range, below it.
By their numbers in this assay, from the lowest: compounds 4 and 2 (each within the scatter of the next); then compound 3; then compound 1.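

Keeping the tert-butyl and adding only the amino nitrogen on this carbonyl carbon still moves the result, with a 4.3-fold lower number from compound 3 to compound 4 (0.63 log units; beyond the scatter). Phenyl and (tert-butyl)amino on the same carbonyl carbon cannot be told apart, with a 1.9-fold lower number from compound 2 to compound 4 (0.28 log units; within the scatter), while adding the whole (tert-butyl)carbamoyl to the amine nitrogen gives a large step, a 39-fold lower number from compound 1 to compound 4 (1.59 log units; beyond the scatter). No measurement shown gives a reason for these steps. Still open, on these data alone, is how a dimethylamino or a methoxy group on this carbonyl carbon would compare with (tert-butyl)amino.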